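The source may hold more compounds than are shown below. What is called first, only, known or untested is meant among the compounds shown, and "the series" means these compounds.

Two measured members of the series frame the step considered here. Compound 1 `COc1cc(O)c(C(=O)/C=C/c2ccc(F)cc2)c(OC)c1` is recorded in a functional assay on NCI-H727 cells (Homo sapiens), read by fluorescence and BrdU incorporation, with a stated time of 48 h, tested at 25 uM (a lower number here means a stronger effect, a higher number a weaker effect of the compound at the concentration tested), as "not active" (no number reported), with no number behind that entry. Going by the values given here, compound 2 `COc1cc(OC)c(C(=O)/C=C/c2ccccc2)c(OC)c1` carries the only number in the set: in this assay compound 2 gives 4.5%, so it stands alone as the sole quantified point, with compound 1 beside it as an entry without a figure. Among the compounds with values here, no pair of measured compounds differs in one place, so no measured step is available to calibrate the size of a single substitution in this assay. Compound 3 `COc1cc(OC)c(C(=O)/C=C/c2ccc(Br)cc2)c(OC)c1` is not yet measured. It differs from compound 2 as follows: bromo in place of hydrogen on an aromatic carbon. Because compound 2 gives 4.5%, a reading that leaves little room for a lower number, the expected step is a number 3.5 percentage points higher from compound 2 to compound 3 (within the scatter), a change expected to stay within the scatter of repeated measurements in this assay. Compound 3 is therefore estimated at 8% in this assay, with a range from 2% to 25%.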

Compound 3, a percentage reported as activity, at one concentration (the size of the read-out at that concentration, not a potency): 6%
Compound 3: the middle estimate sits 2 percentage points above what was measured; low and high end bracket the measured number.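

In this assay, going by these compounds alone, bromo in place of hydrogen on an aromatic carbon, para to a large group, gives a number 1.5 percentage points higher from compound 2 to compound 3 (within the scatter), the first measured step that differs in one place. This position therefore accepts the change from phenyl to 4-bromophenyl, with one added heavy atom, without a readable shift, and the two readings cannot be told apart; this gives the series its first calibration of a single substitution, although it rests on one pair and one substituent. Nothing available bears on why this step has the size it has.

Still open, going by these compounds, is whether a group of another kind on the same aromatic carbon, such as a dimethylamino group, a carboxylic acid or a longer alkoxy chain, would also leave the reading within the scatter of compound 2, since bromo is the only substituent tested there on this core. Compound 1 differs from compound 2 and from compound 3 in more than one place, so its entry cannot show whether the bromo result carries over to a core with a hydroxy group.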